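Notes on a fused bicyclic series in a cytotoxicity assay

The compounds below may be only part of what the source reports. "The series", "measured", "known", "first", "only" and "open" are said of these compounds alone.

Within the data shown here, compound 1 `O[C@@H]1[C@@H](O)[C@H](c2ccccc2)O[C@@H]2CO[C@@H](c3ccc4ccccc4c3)O[C@@H]12` is the one member of the series with a result in a functional assay on HEL cells (Homo sapiens) for cytotoxicity; a higher number here means that more compound is tolerated, a lower number that less compound is tolerated. In this assay compound 1 gives 21 ug/mL. Compound 2 `CO[C@@H]1[C@@H](OC)[C@H](c2ccccc2)O[C@@H]2CO[C@@H](c3cccs3)O[C@@H]12` carries methoxy groups in place of the two hydroxyls of compound 1 and a thiophen-2-yl group on the saturated ring carbon; in this assay compound 2 is recorded as "not determined" (no result reported), so compound 2 stands on no number at all and cannot be set against compound 1.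

Compound 3 `CO[C@@H]1[C@@H](OC)[C@H](c2ccccc2)O[C@@H]2CO[C@@H](c3ccc(C(F)(F)F)cc3)O[C@@H]12` is the next member to go into this assay. It differs from compound 2 in one place: 4-(trifluoromethyl)phenyl in place of thiophen-2-yl on a saturated ring carbon. With compound 2 lacking a number, no direction can be read off for this step; the expectation is a step within the usual scatter of this assay, with nothing that argues for a move beyond it in either sense.

Taking compound 1 as the only anchor, the tolerated concentration of compound 3 in this assay is expected to come out near 20 ug/mL, with an estimated range from 8 ug/mL to 60 ug/mL.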

Compound 3, half-maximal cytotoxic concentration: > 50 ug/mL
Compound 3: a limit, no number; the forecaster's own chance of this, stated with the estimate: 25%; middle value at least 2.5-fold (0.39 log units) from the limit.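

No step can be read between compound 2 and compound 3, since compound 2 has no result in this assay. Compound 3 gives > 50 ug/mL, which is a limit and not a number. The compounds shown leave open whether exchanging thiophen-2-yl for 4-(trifluoromethyl)phenyl on the shared core changes the tolerated concentration at all, and in which direction.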